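The source may hold more compounds than are shown below. What is called first, only, known or untested is meant among the compounds shown, and "the series" means these compounds.

The measured compounds:

Compound 1 `FC(F)=C(F)CCSc1nnc(S)s1`: in a functional assay on MCF7 cells (Homo sapiens) for cytotoxicity, read by MTT assay, with a stated time of 48 h (on this read-out lower numbers stand for stronger inhibition and higher numbers for weaker inhibition), compound 1 gives > 120000 nM, which is a limit of the assay and not a number.
Compound 2 `FC(F)=C(F)CCSc1nc2ccccc2[nH]1`: in this assay compound 2 gives > 120000 nM, likewise a limit of the assay.
Compound 3 `FC(F)(Cl)C(F)(Cl)CCSc1nc2ccccc2s1`: in this assay compound 3 gives > 120000 nM, again only a limit.

Compound 2 therefore stands nowhere distinct on these numbers: its result is a limit, and all three values shown sit at the same place, as stated by the limit of > 120000 nM in this assay, at which 3 of the 3 values shown sit. No pair of these compounds differs in a single place, so no measured step can be drawn from them, and there is no sign of an ordering among them.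

Compound 4 `FC(F)=C(F)CCSc1nc2ccc(OC(F)F)cc2[nH]1` is the next compound to be measured. It departs from compound 2 by difluoromethoxy in place of hydrogen on an aromatic carbon. Within the data shown here, since none of the measured compounds gives a number in this assay, there is no step on which to found a direction, and the expectation for this change is none beyond the usual scatter. Compound 4 is accordingly expected to remain near the limit, with an estimated step that the limit leaves unreadable from compound 2 to compound 4. The estimate for compound 4 in this assay is 150000 nM, within a range from 40000 nM to 500000 nM, with a substantial chance that only a limit is reported.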

Compound 4, half-maximal inhibitory concentration: > 120000 nM
Compound 4: only a limit was reported (the forecaster's own chance of this, stated with the estimate: 75%); the middle value is on the limit's open side.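

Compound 2 and compound 4 both stand at a limit of the assay and not at a number, so no step can be read between them: the limit of > 120000 nM in this assay, at which 4 of the 4 values shown sit.

The compounds shown leave open what number any of them would give in this assay, and whether difluoromethoxy in place of hydrogen on an aromatic carbon changes the result at all.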